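Fluoro Substitution Carried Over to a Second Core

A few compounds are considered here, and "the series" means these few. Any claim that something is new, unique, unknown or untested is made for them only; others in the source may bear on it.

Two pairs of compounds share one small change, and a measured pair gives a yardstick for an unmeasured one. Compound 1 `S=c1n(-c2ccc(Cl)cc2)c(=S)n2n1CCCC2` and compound 2 `Fc1cc(Cl)ccc1-n1c(=S)n2n(c1=S)CCCC2` differ by fluoro in place of hydrogen on an aromatic carbon. In a functional assay on the whole organism for inhibition, with Echinochloa esculenta as the target (on this read-out lower numbers stand for stronger inhibition and higher numbers for weaker inhibition), compound 1 gives 89.1 nM, and compound 2 gives 91.2 nM; the step of a 1.0-fold higher number from compound 1 to compound 2 (0.01 log units; within the scatter) shows that the added fluoro left the read-out essentially where it was.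

Compound 3 `S=c1s/c(=N\c2ccc(Cl)cc2)n2n1CCCC2` is built on a different core. In this assay compound 3 gives 407 nM, the highest number of the three measured compounds, and its gap to both compound 1 and compound 2 lies beyond the scatter. How the core of compound 3 differs from the core of compound 1 is not broken down here.

Compound 4 `Fc1cc(Cl)ccc1/N=c1\sc(=S)n2n1CCCC2` is compound 3 carrying the same change: fluoro in place of hydrogen on an aromatic carbon. The place of the new fluoro is described in the same words for both pairs, so the change is the same one. Within the data shown here, the only guide is the measured pair, in which the fluoro made no difference worth the name, so the step from compound 3 to compound 4 in this assay is expected to be about a 1.0-fold higher number from compound 3 to compound 4 (0.00 log units; within the scatter), because the same change gave a 1.0-fold higher number from compound 1 to compound 2 (0.01 log units; within the scatter). Among the measured compounds shown here, the core itself changes nothing about this reasoning, since no second example on the core of compound 3 exists. Compound 4 is therefore estimated at 410 nM, with a plausible range from 200 nM to 850 nM.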

Compound 4, half-maximal inhibitory concentration: 158 nM
For compound 4 the middle estimate is 2.6-fold (0.41 log units) above the measured one; measured number below the stated range.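

On the core of compound 3, the added fluoro moves the read-out in this assay by a 2.6-fold lower number from compound 3 to compound 4 (0.41 log units; beyond the scatter), a modest step that is larger than repeat measurements would usually produce, whereas on the core of compound 1 the same change gives only a 1.0-fold higher number from compound 1 to compound 2 (0.01 log units; within the scatter). Taken alone, the two steps seem to tell different stories, yet the gap between them is small enough that each step's own measurement noise could account for it: the same change on two cores in this assay, a 1.0-fold higher number (0.01 log units; within the scatter) from compound 1 to compound 2 and a 2.6-fold lower number (0.41 log units; beyond the scatter) from compound 3 to compound 4, 2.6-fold (0.42 log units) apart, within the scatter of two such steps. This shows that the change can be carried to the second core without any sign of raising the number, but it does not show that the two cores truly respond alike or truly respond differently, since each core offers just one pair.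

On these data alone, the aromatic ring in these compounds carries only chloro and fluoro groups, so it remains open how a methyl or methoxy group at the same place would behave on either core. As far as these compounds go, it also remains open whether the step from hydrogen to fluoro would stay the same size on each core if a bromo group stood in place of the chloro group.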